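Swapping a Chlorophenyl Arm on a Shared Core

A few compounds are considered here, and "the series" means these few. Any claim that something is new, unique, unknown or untested is made for them only; others in the source may bear on it.

Two compounds on the same core have been given numbers in a functional assay on BGC-823 cells (Homo sapiens) for cytotoxicity, read by CCK-8 assay, with a stated time of 72 h; a higher number here means a weaker inhibitor, a lower number a stronger inhibitor. Compound 2 `C=CCn1c(=O)/c(=C\c2ccccc2C(F)(F)F)[nH]c(=O)/c1=C\c1ccccc1OC` gives 5100 nM, and compound 3 `C=CCn1c(=O)/c(=C\c2ccccc2Cl)[nH]c(=O)/c1=C\c1ccccc1OC` gives 4600 nM. The step of a 1.1-fold lower number from compound 2 to compound 3 (0.04 log units; within the scatter) shows that these two sit together, so on the numbers alone compound 3 cannot be separated from compound 2. A third member, compound 1 `C=CCn1c(=O)/c(=C\c2ccc(Cl)c(Cl)c2)[nH]c(=O)/c1=C\c1ccccc1`, carries a 3,4-dichlorophenyl group and is reported in this assay as "not active" (no number reported).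

Compound 4 `C=CCn1c(=O)/c(=C\c2ccc(Cl)c(Cl)c2)[nH]c(=O)/c1=C\c1ccccc1OC` is not yet measured. It differs from compound 3 by 3,4-dichlorophenyl in place of 2-chlorophenyl on a double-bonded chain carbon bound to an aromatic carbon. Within the data shown here, no measured step covers this exact change. Among the measured compounds shown here, the only related evidence is compound 1, which bears the same 3,4-dichlorophenyl group and whose result in this assay is "not active" (no number reported), though its other aryl group also differs from that of compound 4. On that basis the step of a 3.3-fold higher number from compound 3 to compound 4 (0.51 log units; beyond the scatter) is expected to be a loss of potency. Compound 4 is estimated at 15000 nM, within 5000 nM to 60000 nM, with a real chance that only an inactive result is reported.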

Compound 4, half-maximal inhibitory concentration: "not active" (no number reported)
Compound 4 has no reported number here; no gap can be computed for the estimate.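

Among these compounds, compound 4 is reported in this assay as "not active" (no number reported) and so no step from compound 3 to compound 4 can be read. Nothing shown explains this result. The compounds shown leave open how compound 4 would compare numerically with compound 3.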